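The source may report more compounds than this note shows. Statements on the series, on what has been measured and on what is new or still open speak of the compounds shown alone.

Measured compounds in a functional assay on HEK293 cells for negative allosteric modulation of metabotropic glutamate receptor 5 (Homo sapiens), read by FLIPR and calcium flux; on this read-out higher numbers stand for weaker inhibition and lower numbers for stronger inhibition:
compound 1 `O=C(Nc1cc(Cl)ccc1O)c1noc2c1CCC2`: 373 nM
compound 2 `Cc1cccc(NC(=O)c2cc(-c3ccccc3)n(C)n2)n1`: 95 nM
compound 3 `Cc1cccc(NC(=O)c2nn(C)c(-c3ccccc3)c2C)n1`: 4.4 nM

Compound 3 stands at the lowest number of the three in this assay, clearly separated from compound 2 and compound 1. For the measured compounds named here, the only one-place change among the measured compounds, a 22-fold lower number from compound 2 to compound 3 (1.33 log units; beyond the scatter), concerns a methyl on the five-membered ring and offers no direct guidance on the change now at hand. Compound 4 `Cc1cccc(NC(=O)c2nn(C)c(C3CCCCC3)c2C)n1` differs from compound 3 by cyclohexyl in place of phenyl on an aromatic carbon. No measured pair shows an exchange of this kind, so the expectation rests on the general weight of such a change rather than on a shown step. For compound 4 the account expects a moderate rise in number, a 4.5-fold higher number from compound 3 to compound 4 (0.66 log units; beyond the scatter), and estimates compound 4 at 20 nM, with a range from 4 nM to 120 nM.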

Compound 4, half-maximal inhibitory concentration: 25 nM
The estimate for compound 4 lay 1.3-fold (0.10 log units) below the measured number; the measured number falls inside the stated range.
By their numbers in this assay, from the lowest: compound 3; then compound 4; then compound 2; then compound 1.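

Placing cyclohexyl in place of phenyl on this aromatic carbon gives a 5.7-fold higher number from compound 3 to compound 4 (0.75 log units; beyond the scatter), a modest step. At this position, a six-membered non-aromatic ring of carbon only therefore retains much of the inhibition seen with the aromatic ring, at a measurable cost. Nothing available here accounts for the size of this step.

The compounds shown leave open how a smaller ring such as cyclopentyl or an open group such as tert-butyl would fare here. They also leave open the effect of a pyridine ring or a piperidine ring at this position.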